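This account rests on a few compounds, and the source may have more. Where it says the series, first, only, none or still open, it means among the compounds named here.

In a functional assay on MV4-11 cells (Homo sapiens) for antiproliferative activity, read by CellTiter-Glo, with a stated time of 72 h (a lower number here means a stronger inhibitor of growth, a higher number a weaker inhibitor of growth), compound 1 (`COC[C@H](C)N[C@H]1CC[C@H](Nc2cc(-c3csc(NCC4CCOCC4)n3)c(Cl)cn2)CC1`) gives 440 nM and compound 2 (`COC[C@@H](C)N[C@H]1CC[C@H](Nc2cc(-c3csc(NCC4(C#N)CCOCC4)n3)c(Cl)cn2)CC1`) gives 14 nM as the lower of the two numbers, a gap beyond the scatter. Compound 3 (`COC[C@H](C)N[C@H]1CC[C@H](Nc2cc(-c3csc(NCC4(C#N)CCOCC4)n3)c(Cl)cn2)CC1`) awaits measurement and departs from compound 2 by the two compounds have the same atoms and bonds and differ only in configuration as drawn: 2 of 3 stereo elements differ; a stereocentre at a saturated chain carbon is drawn R in compound 2 and S in compound 3; a stereocentre at a saturated ring carbon is drawn R in compound 2 and S in compound 3 with the same atoms and bonds. For the measured compounds named here, no measured pair shows what such a change does, so a modest weakening in this assay is expected, an estimated 2.5-fold higher number from compound 2 to compound 3 (0.40 log units; beyond the scatter) that may lie close to the scatter. Compound 3 is estimated at 35 nM with an expected range from 10 nM to 120 nM in this measurement.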

Compound 3, concentration for 50% growth inhibition: 121 nM
Beside the measured number, compound 3's estimate is 3.5-fold (0.54 log units) below it; the measured number lies above the stated range.
By their numbers in this assay, from the lowest: compound 2; then compound 3; then compound 1.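

In this assay the drawn configuration matters on its own, shown by an 8.6-fold higher number from compound 2 to compound 3 (0.94 log units; beyond the scatter). This step can be set down to configuration alone because of one fact: the fact that compounds 2 and 3 differ only in the configuration as drawn. With the configuration of compound 1 kept, cyano in place of hydrogen on a saturated ring carbon still helps, giving a 3.6-fold lower number from compound 1 to compound 3 (0.56 log units; beyond the scatter). As far as these compounds go, the chain and ring stereocentres change together, so the share of each stays open. Also open, from the compounds shown here alone, is how a fluorine or a carboxamide would compare with cyano on that saturated ring carbon.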